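This account rests on a few compounds, and the source may have more. Where it says the series, first, only, none or still open, it means among the compounds named here.

Measured so far:
- compound 1 `CC(C)N1CCN(Cc2csc(N)c2C(=O)c2ccc(Cl)cc2)CC1`: -1%
- compound 2 `Nc1scc(CN2CCN(c3ccc(F)cc3Cl)CC2)c1C(=O)c1ccc(Cl)cc1`: 6.1%
- compound 3 `Nc1scc(CN2CCN(c3ccc(F)c(F)c3)CC2)c1C(=O)c1ccc(Cl)cc1`: -3.2%

All three compounds share one core and differ only in the group on an amine nitrogen in a ring. In a functional assay on CHO cells with adenosine receptor A1 (Homo sapiens) as the target, read by cAMP accumulation and immunoassay, with a stated time of 6 min, tested at 0.01 uM (on this read-out higher numbers stand for a weaker effect at the one concentration tested and lower numbers for a stronger effect), compound 3 gives the lowest of the three numbers, yet the nearest number, that of compound 1, and the furthest, that of compound 2, both lie within the scatter of it, so no order among the three can be read from these values. The measured steps confirm this: a number 7.1 percentage points higher from compound 1 to compound 2 (within the scatter), a number 2.2 percentage points lower from compound 1 to compound 3 (within the scatter) and a number 9.3 percentage points lower from compound 2 to compound 3 (within the scatter) are each inside the scatter, whether an isopropyl or one of two halogenated phenyl groups sits on that nitrogen.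

Compound 4 `Nc1scc(CN2CCN(c3cc(Cl)ccc3Cl)CC2)c1C(=O)c1ccc(Cl)cc1` carries the next change at the same place: 2,5-dichlorophenyl in place of 3,4-difluorophenyl on an amine nitrogen in a ring. Within the data shown here, the steps that bear on it are those that alter the same nitrogen substituent, above all a number 9.3 percentage points lower from compound 2 to compound 3 (within the scatter), which swaps one dihalophenyl for another, and a number 2.2 percentage points lower from compound 1 to compound 3 (within the scatter). Neither moved the read-out in this assay beyond the scatter, so a step of no real size is expected here, in no particular direction. For compound 4 the estimate in this assay is 1%, within -10% to 13%, an expected step of a number 4.2 percentage points higher from compound 3 to compound 4 (within the scatter).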

Compound 4, a percentage reported as activity, at one concentration (the size of the read-out at that concentration, not a potency): 13%
Beside the measured number, compound 4's estimate is 12 percentage points below it, and the stated range covers the measured number.
By their numbers in this assay, from the lowest: compounds 3, 1, 2 and 4 (each within the scatter of the next, the first and the last beyond it).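

In this assay the group on the ring nitrogen now gives its first steps beyond the scatter, with a number 16.2 percentage points higher from compound 3 to compound 4 (beyond the scatter) for 2,5-dichlorophenyl in place of 3,4-difluorophenyl and a number 14 percentage points higher from compound 1 to compound 4 (beyond the scatter) for 2,5-dichlorophenyl in place of isopropyl, so the choice of group at this position can shift the read-out. The data do not split cleanly, however: a number 6.9 percentage points higher from compound 2 to compound 4 (within the scatter) for 2,5-dichlorophenyl in place of 2-chloro-4-fluorophenyl stays small, and compound 2 also lies within the scatter of compound 1 and compound 3, so the four compounds form an overlapping run rather than two separate groups. The two phenyl groups in the step to compound 4 match in heavy-atom count, ring type, hydrogen-bond donors and acceptors, and charge, differing in the halogen and its placement, and no measurement at hand accounts for the step.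

Going by these compounds, whether the step follows the kind of halogen or its placement remains open, and 2,5-difluorophenyl or 3,4-dichlorophenyl on this nitrogen would separate the two. On these data alone, how this position responds to an unsubstituted phenyl, a carboxylic acid or a longer alkyl chain also remains open.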